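The source may hold more compounds than are shown below. What is called first, only, known or untested is meant among the compounds shown, and "the series" means these compounds.

Among the compounds with values here, only two compounds built on the shared core have been read so far in a functional assay on NCI-H460 cells (Homo sapiens) for inhibition, read by MTT assay, with a stated time of 24 h, tested at 1 ug/mL; a higher number here means more inhibition of growth at the concentration tested, a lower number less inhibition of growth. There compound 1 (`O=C(CCCCC1CCSS1)NO`) gives 0.64% of inhibition, and compound 2 (`O=C(CCCCC1CCSS1)Nc1ccccc1Cl`) gives 10.1% of inhibition. These two values lie within the usual scatter of each other, so compound 1 cannot be ranked against compound 2, and both stand as modest readings at the single concentration tested.

Compound 3 (`O=C(CCCCC1CCSS1)Nc1ccccn1`) has not yet been measured. It differs from compound 1 in one place, with pyridin-2-yl in place of hydroxy on an amide-type nitrogen. Counted out, the change reads (pyridin-2-yl in place of hydroxy on an amide-type nitrogen) and leaves the rest of the core of compound 1 untouched.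

No measured pair yet shows a single change of this kind in this assay directly. Compound 2, which likewise has no hydroxy on that nitrogen, gives 10.1% there, so no step beyond the scatter is expected. The expected change is a number 7.4 percentage points higher from compound 1 to compound 3 (within the scatter) in size, with no clear direction. For compound 3 the estimated value is 8% with an expected range from 0% to 20% in this read-out.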

Compound 3, percent growth inhibition at one concentration: 0.81%
The estimate for compound 3 lay 7.2 percentage points above the measured number; the range from low to high includes it.
By their numbers in this assay, from the lowest: compounds 1, 3 and 2 (each within the scatter of the next).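

In this assay, within the data shown here, the exchange of hydroxy for pyridin-2-yl on the amide-type nitrogen gives a number 0.2 percentage points higher from compound 1 to compound 3 (within the scatter) and is the first direct step read at this position. Replacing the small hydroxy with a whole six-membered aromatic ring, which also removes the hydrogen-bond donor of the hydroxy, therefore produces no change that can be told apart from the scatter, and the reading of the core of compound 1 stays where it was at the single concentration tested. Nothing measured here offers an explanation for why these two groups read alike, and the result alone cannot supply one.

The compounds shown leave open whether any other group on this amide-type nitrogen, such as a simple methyl, an aminoethyl chain or a longer chain ending in a carboxylic acid, would move the reading beyond the scatter. They also leave open whether hydroxy and pyridin-2-yl would still read alike at higher concentrations or after a longer exposure of the cells.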